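Methoxycarbonyl to ethoxycarbonyl in a series bound by limits

This account rests on a few compounds, and the source may have more. Where it says the series, first, only, none or still open, it means among the compounds named here.

In a functional assay on the whole organism for antagonist activity, with Mus musculus as the target (a lower number here means that less compound is needed, a higher number that more compound is needed for the effect), compound 2 (`COC(=O)N(C)C(C)C#CCN1CCCC1`) gives > 100 mg/kg, a limit and not a number. That is the limit of > 100 mg/kg in this assay, at which 2 of the 3 values shown sit. Compound 3 (`COC(=O)N(C)C(C)C#CCn1ccnc1`) gives > 100 mg/kg, also a limit. Compound 1 (`COC(=O)N(C)CC#CCN1CCCC1`) gives > 10 mg/kg, likewise a limit. That is the limit of > 10 mg/kg in this assay, at which 1 of the 3 values shown sits. Among the measured compounds shown here, no compound therefore has a measured dose for half-maximal effect.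

Compound 4 (`CCOC(=O)N(C)C(C)C#CCN1CCCC1`) differs from compound 2 at one place: methyl in place of hydrogen on a saturated chain carbon bound to an oxygen next to a carbonyl group. This is methyl in place of hydrogen on a saturated chain carbon bound to an oxygen next to a carbonyl group, so methoxycarbonyl becomes ethoxycarbonyl.

Two measured steps are available: a step that the two limits leave unreadable from compound 1 to compound 2, and a step that the two limits leave unreadable from compound 2 to compound 3. Neither has a readable size, and neither alters the methoxycarbonyl group, so neither bears directly on this change. They give no basis for a direction in this assay, and no step beyond the scatter is expected. The expected change is a step that the limit leaves unreadable from compound 2 to compound 4. A report of a limit alone remains the most likely outcome. For compound 4 the estimated value is 150 mg/kg, with an expected range of 60 mg/kg to 400 mg/kg.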

Compound 4, dose for half-maximal effect: > 100 mg/kg
Compound 4 gave a limit, no number; the forecaster's own chance of this, stated with the estimate: 80%; the middle value is on the limit's open side.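

Compound 4 gives > 100 mg/kg in this assay, a limit and not a number. Compound 2 is also reported only as a limit, so no new step can be read between compound 2 and compound 4. The compounds shown leave open what dose for half-maximal effect either compound has, and whether methoxycarbonyl to ethoxycarbonyl shifts it at all.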